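The source may hold more compounds than are shown below. What is called first, only, known or untested is meant among the compounds shown, and "the series" means these compounds.

Measured compounds:
compound 1, `COc1cc(NC(=O)Nc2cc(Nc3ccc(OC)c(C)c3)ncn2)cc(OC)c1`, in a functional assay on NCI-H520 cells (Homo sapiens) for inhibition, read by MTT assay, with a stated time of 48 h, tested at 10 uM (a higher number here means more inhibition at the concentration tested (going by the name of the read-out), a lower number less inhibition), compound 1 gives 13.5%;
compound 2, `COc1ccc(Br)cc1Nc1cc(NC(=O)Nc2c(Cl)cccc2Cl)ncn1`, compound 2 gives 45%;
compound 3, `COc1ccc(F)cc1Nc1cc(NC(=O)Nc2c(Cl)cccc2Cl)ncn1`, compound 3 gives 38.1%.

Compound 2 holds the highest of the three numbers in this assay; compound 3 lies nearest to it, within the scatter, while compound 1 lies well beyond it, lower. The unmeasured compound 4, `Cc1ccc(Nc2cc(NC(=O)Nc3c(Cl)cccc3Cl)ncn2)cc1F`, is reached from compound 2 by one change: 3-fluoro-4-methylphenyl in place of 5-bromo-2-methoxyphenyl on a nitrogen on an aromatic ring. Among the measured compounds shown here, only one measured step touches the same aryl group, a number 6.9 percentage points lower from compound 2 to compound 3 (within the scatter), and it stayed within the scatter, so a swap of the halogen there did little. Compound 1 differs from compound 2 in more than one place and its lower value cannot be tied to the aryl alone. For the measured compounds named here, the change to compound 4 is larger than the one from compound 2 to compound 3, so a modest drop is expected rather than none, though the data give no firm ground for its size. Compound 4 is therefore estimated at 36% in this assay, with a range from 16% to 54%, which means an expected step of a number 9 percentage points lower from compound 2 to compound 4 (within the scatter).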

Compound 4, a percentage reported as inhibition, at one concentration (the size of the read-out at that concentration, not a potency): 33.5%
The estimate for compound 4 lay 2.5 percentage points above the measured number, and the stated range covers the measured number.
By their numbers in this assay, from the lowest: compound 1; then compounds 4, 3 and 2 (each within the scatter of the next, the first and the last beyond it).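

In this assay, among the compounds shown here, the exchange of the whole aryl group on a nitrogen on an aromatic ring gives a number 11.5 percentage points lower from compound 2 to compound 4 (beyond the scatter) in a modest size, the first step at this position to leave the scatter. Read from the fluoro compound, the same exchange gives a number 4.6 percentage points lower from compound 3 to compound 4 (within the scatter) and stays inside it, so only the bromo compound stands clear of compound 4. Nothing measured here bears on why the number moves at this position.

Since the methoxy group, the halogen and the methyl group all change together in this exchange, the compounds shown leave open which of them carries the step. They also leave open how an aryl group bearing an amine or a carboxylic acid, or a longer alkyl chain in place of the aryl group, would read in this assay at this nitrogen.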